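Para-methyl on the benzylamine of the trimethoxystyryl series

The source may hold more compounds than are shown below. What is called first, only, known or untested is meant among the compounds shown, and "the series" means these compounds.

Three compounds of the series carry the shared core with the trimethoxystyryl arm and have been read in an ADME assay on RAW264.7 cells (Mus musculus) for cytotoxicity, read by MTT assay; on this read-out lower numbers stand for stronger inhibition and higher numbers for weaker inhibition; all three sit at the upper limit of the measurement. Compound 1 `COc1ccc(Nc2nc(/C=C/c3cc(OC)c(OC)c(OC)c3)nc3ccsc23)cc1` gives a limit of > 50000 nM. Compound 2 `COc1cc(/C=C/c2nc(Nc3ccc(O)cc3)c3sccc3n2)cc(OC)c1OC` likewise gives a limit of > 50000 nM. Compound 3 `COc1cc(/C=C/c2nc(NCc3ccccc3)c3sccc3n2)cc(OC)c1OC` also gives only a limit, > 50000 nM. Because all three values are limits, the three measured steps stay unreadable: a step that the two limits leave unreadable from compound 1 to compound 2, a step that the two limits leave unreadable from compound 1 to compound 3 and a step that the two limits leave unreadable from compound 2 to compound 3, as the limit of > 50000 nM in this assay, at which 3 of the 3 values shown sit, sums up.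

Compound 4 `COc1cc(/C=C/c2nc(NCc3ccc(C)cc3)c3sccc3n2)cc(OC)c1OC` differs from compound 3 in one place: methyl in place of hydrogen on an aromatic carbon. Among the compounds with values here, none of the measured steps touches this position; the closest, from compound 1 and compound 2 to compound 3, exchanges the whole group on the nitrogen and remains unreadable. There is therefore no measured step to size this change against, and no reason to expect compound 4 to leave the limit at which the others sit.

Compound 4 is expected to give 70000 nM in this assay, within 30000 nM to 200000 nM, which would mean a step that the limit leaves unreadable from compound 3 to compound 4 from compound 3.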

Compound 4, half-maximal inhibitory concentration: > 50000 nM
Compound 4 gave a limit, no number; the forecaster's own chance of this, stated with the estimate: 85%; the middle value lies beyond the limit too.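

In this assay the steps from compound 1, compound 2 and compound 3 to compound 4 cannot be read, because all four compounds stop at the same limit: the limit of > 50000 nM in this assay, at which 4 of the 4 values shown sit. The compounds shown leave open how large the change from benzyl to 4-methylbenzyl is, and at what concentration any of the four reaches half-maximal inhibition.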